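The source may report more compounds than this note shows. Statements on the series, on what has been measured and on what is new or still open speak of the compounds shown alone.

Compound 1, `Oc1ccc(O)c(-c2cc(-c3ccc(Cl)cc3)nn2-c2ccccc2)c1`, gives 8010 nM in a functional assay on cells (Cancer cell lines, Homo sapiens) for cytotoxicity, read by sulforhodamine B assay, with a stated time of 48 h; a lower number here means a stronger inhibitor of growth, a higher number a weaker inhibitor of growth.
Compound 2, `NS(=O)(=O)c1ccc(-n2nc(-c3ccccc3)cc2-c2cc(O)ccc2O)cc1`, gives 81300 nM in this assay.

Compound 2 stands with the higher of the two numbers; its value lies well above that of compound 1, a gap beyond the scatter. Going by the values given here, compound 1 and compound 2 differ in more than one place, so no single step between them can be read off; only their two values can be set side by side.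

Compound 3, `NS(=O)(=O)c1ccc(-n2nc(-c3ccc(Cl)cc3)cc2-c2cc(O)ccc2O)cc1`, has not yet been measured in this assay. It arises from compound 2 by chloro in place of hydrogen on an aromatic carbon. Among the compounds with values here, no measured pair shows this change on its own, so the size of its effect rests on no direct comparison. Within the data shown here, compound 1, the one compound here bearing a 4-chlorophenyl group, gives the lower number, but it differs from compound 2 elsewhere as well, so its value cannot be ascribed to the chloro alone. The expectation is a modest move toward a lower number, a 2.0-fold lower number from compound 2 to compound 3 (0.31 log units; beyond the scatter), though a change no larger than the scatter would not surprise. Compound 3 is therefore estimated at 40000 nM, between 12000 nM and 120000 nM.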

Compound 3, concentration for 50% growth inhibition: 14700 nM
For compound 3 the middle estimate is 2.7-fold (0.43 log units) above the measured one; low and high end bracket the measured number.
By their numbers in this assay, from the lowest: compounds 1 and 3 (each within the scatter of the next); then compound 2.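

In this assay, going by these compounds alone, the change from phenyl to 4-chlorophenyl now has a direct reading, which no earlier pair could give: with the sulfamoyl group in place, the measured step is a 5.5-fold lower number from compound 2 to compound 3 (0.74 log units; beyond the scatter) and stands as the largest effect that can be tied to a single change in this small set. Within the data shown here, the second new pair isolates the sulfamoyl group for the first time, and with the 4-chlorophenyl group in place it gives a 1.8-fold higher number from compound 1 to compound 3 (0.26 log units; within the scatter), so this change does not separate the two compounds. Taken together, the two steps show that, of the single changes that can be read here, the chloro at this position carries a difference beyond the scatter, while the sulfamoyl group does not; nothing available bears on the reason for either result.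

From the compounds shown here alone, the sulfamoyl step is known only alongside the 4-chlorophenyl group, and the chloro step only alongside the sulfamoyl group, so whether either holds in the other setting stays open. Going by these compounds, it also remains open how a bromo or methoxy group would read in place of the chloro, or how a carboxylic acid would read in place of the sulfamoyl group.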